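The compounds below may be only part of what the source reports. "The series", "measured", "known", "first", "only" and "open" are said of these compounds alone.

Within the data shown here, in an assay on cells for inhibition of protein deacetylase HDAC6 (Homo sapiens), read by fluorescence, with stated times of 15 min and 60 min (on this read-out higher numbers stand for weaker inhibition and lower numbers for stronger inhibition), compound 1 `Cc1cc(-c2ccc(F)cc2)n(Cc2ccc(C(=O)NO)cc2)n1` gives 20 nM, the lower of the two numbers so far. Compound 2 `Cc1ccc(-c2cc(C)nn2Cc2ccc(C(=O)NO)cc2)cc1` gives 29 nM in this assay, and the step from compound 1 to compound 2 is a 1.5-fold higher number from compound 1 to compound 2 (0.16 log units; within the scatter). Compound 3 `O=C(NO)c1ccc(Cn2nc(Cc3ccccc3)cc2-c2ccc(F)cc2)cc1` carries phenyl in place of hydrogen on a saturated chain carbon bound to an aromatic carbon. Among the measured compounds shown here, that change touches a place no measured step addresses; the one measured step concerns a different position and lies within the scatter, so no shift beyond the scatter is expected, and the step from compound 1 to compound 3 is expected to be a 1.3-fold higher number from compound 1 to compound 3 (0.10 log units; within the scatter). Compound 3 is therefore estimated at 25 nM, with a range from 8 nM to 80 nM.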

Compound 3, half-maximal inhibitory concentration: 420 nM
Beside the measured number, compound 3's estimate is 17-fold (1.23 log units) below it, outside the stated range (above it).
By their numbers in this assay, from the lowest: compounds 1 and 2 (each within the scatter of the next); then compound 3.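

Going from methyl to benzyl on a saturated chain carbon bound to an aromatic carbon brings a 21-fold higher number from compound 1 to compound 3 (1.32 log units; beyond the scatter) in this assay and so shows that inhibition responds to a change at this position, which the earlier step did not address. Here the added phenyl comes with clearly weaker inhibition. No evidence at hand explains this loss.

The compounds shown leave open whether a smaller group at this carbon, such as ethyl, would also weaken inhibition. They also leave open how an amine or a carboxylic acid on the same carbon would compare.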